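Clearance in rat across a configurational change

The source may hold more compounds than are shown below. What is called first, only, known or untested is meant among the compounds shown, and "the series" means these compounds.

Measured in an ADME assay on the whole organism for pharmacokinetics, with Rattus norvegicus as the target, at a dose of 3 mg/kg by the intravenous route; on this read-out lower numbers stand for slow clearance and higher numbers for fast clearance:
compound 1 `COC(=O)N[C@H](C(=O)N1CCC[C@H]1C(=O)Nc1ccc([C@@H]2CC[C@@H](c3ccc(NC(=O)[C@@H]4CCCN4C(=O)[C@@H](NC(=O)OC)[C@@H](C)OC)cc3)N2c2ccc(F)cc2)cc1)[C@@H](C)OC`: 56.7 mL/min/kg
compound 2 `COC(=O)N[C@H](C(=O)N1CCC[C@H]1C(=O)Nc1ccc([C@@H]2CC[C@@H](c3ccc(NC(=O)[C@@H]4CCCN4C(=O)[C@@H](NC(=O)OC)C(C)(C)C)cc3)N2c2ccc(F)cc2)cc1)C(C)(C)C`: < 6.5 mL/min/kg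

The value of compound 2 is a limit of the assay, not a number (the limit of < 6.5 mL/min/kg in this assay, at which 1 of the 2 values shown sits). Compound 2 thus stands at the slow end of the numbers shown. Compound 3 `COC(=O)N[C@H](C(=O)N1CCC[C@H]1C(=O)Nc1ccc([C@H]2CC[C@H](c3ccc(NC(=O)[C@@H]4CCCN4C(=O)[C@@H](NC(=O)OC)C(C)(C)C)cc3)N2c2ccc(F)cc2)cc1)C(C)(C)C` keeps every atom of compound 2 and differs only in configuration: the two compounds have the same atoms and bonds and differ only in configuration as drawn: 2 of 6 stereo elements differ; a stereocentre at a saturated ring carbon is drawn S in compound 2 and R in compound 3; a stereocentre at a saturated ring carbon is drawn S in compound 2 and R in compound 3. Among the compounds with values here, no step between measured compounds is known here, so the size of this change is open; a step beyond the scatter, toward faster clearance, is thought possible but not established. For compound 3 the estimate in this assay is 10 mL/min/kg, spanning 5 mL/min/kg to 25 mL/min/kg, which means an expected step of an at least 1.5-fold higher number from compound 2 to compound 3 (0.18 log units; that floor lies within the scatter).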

Compound 3, clearance: 1.67 mL/min/kg
The estimate for compound 3 lay 6.0-fold (0.78 log units) above the measured number; measured number below the stated range.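

Within the data shown here, no step from compound 2 to compound 3 can be read, as the value of compound 2 is a limit and not a number. Going by these compounds, whether the two configurations truly differ in clearance stays open.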